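Sulfonyl aryl exchange on compound 2: cytotoxicity notes

The source may hold more compounds than are shown below. What is called first, only, known or untested is meant among the compounds shown, and "the series" means these compounds.

Measured in an ADME assay on cells (Hepatocyte, Mus musculus) for cytotoxicity, read by MTT assay, with a stated time of 24 h; a higher number here means that more compound is tolerated, a lower number that less compound is tolerated:
- compound 1 `Cc1ccc(-c2nn(-c3ccccc3)cc2-c2nc3ccccc3[nH]2)cc1`: > 300000 nM, a limit and not a number
- compound 2 `Cc1ccc(-c2nn(-c3ccccc3)cc2-c2nc3ccccc3n2S(=O)(=O)c2cc(C)ccc2C)cc1`: 231000 nM

Compound 1 stands at the limit of > 300000 nM in this assay, at which 1 of the 2 values shown sits. Going by the values given here, compound 2 gives 231000 nM, the only actual number so far in this assay, so it has no numerical comparator.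

Compound 3 `Cc1ccc(-c2nn(-c3ccccc3)cc2-c2nc3ccccc3n2S(=O)(=O)c2ccc(Br)cc2)cc1` carries 4-bromophenyl in place of 2,5-dimethylphenyl on a sulfonyl sulfur. The sulfonyl link to the aromatic nitrogen stays in place.

Among the compounds with values here, only one measured step bears on this change: an at least 1.2-fold lower number from compound 1 to compound 2 (0.11 log units; that floor lies within the scatter). That step adds the whole sulfonyl group, whereas the present change exchanges only the aryl group on it. Within the data shown here, no measured step exchanges one such aryl group for another, so the evidence is indirect. Among the measured compounds shown here, with an at least 1.2-fold lower number from compound 1 to compound 2 (0.11 log units; that floor lies within the scatter) as the only guide, no shift beyond the scatter is expected in this assay, and no direction is favoured with any confidence. The expected step is a 1.2-fold lower number from compound 2 to compound 3 (0.06 log units; within the scatter). Compound 3 is estimated at 200000 nM, with an expected range of 90000 nM to 300000 nM.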

Compound 3, half-maximal cytotoxic concentration: > 300000 nM
Compound 3 gave a limit, no number; the forecaster's own chance of this, stated with the estimate: 20%; at least 1.5-fold (0.17 log units) between middle value and limit.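

In this assay, as far as these compounds go, the exchange of 2,5-dimethylphenyl for 4-bromophenyl on a sulfonyl sulfur gives an at least 1.2-fold higher number from compound 2 to compound 3 (0.11 log units; that floor lies within the scatter); this floor alone shows no shift beyond the scatter, and the true size of the step is unknown. The step from compound 1 to compound 3 cannot be read, as both ends are limits. New here is that the sulfonyl link to the aromatic nitrogen does not by itself bring a measured number in this series, as compound 3 keeps that link and still gives only a limit, so most of the series now sits at one value: the limit of > 300000 nM in this assay, at which 2 of the 3 values shown sit.

The compounds shown leave open how a sulfonyl group carrying an amine or a carboxylic acid on its aryl ring, or a longer alkyl chain in place of that ring, would read in this assay. They also do not separate the effect of adding bromine from that of removing the methyl groups, and no compound shown has only one of these changes.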